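The compounds below may be only part of what the source reports. "The series", "measured", "known", "first", "only" and "open" are said of these compounds alone.

In an ADME assay on the whole organism (plasma) for metabolic stability, with Canis familiaris (Canis lupus familiaris) as the target (on this read-out higher numbers stand for a longer-lived compound and lower numbers for a shorter-lived compound), compound 1 (`NC1CCN(C(=O)c2ccc3[nH]c(-c4cc5ccccc5nc4O)cc3c2)C1`) gives 1.1 h and compound 2 (`O=C(NC1CCNC1)c1ccc2[nH]c(-c3cc4ccccc4nc3O)cc2c1`) gives 1.7 h with a 1.5-fold higher number from compound 1 to compound 2 (0.19 log units; within the scatter) as the step between them. Compound 3 (`CN1CCN(S(=O)(=O)c2ccc3[nH]c(-c4cc5ccccc5nc4O)cc3c2)CC1`) stands highest of the three at 6.4 h and lies beyond the scatter of both others. Compound 4 (`NC1CCN(S(=O)(=O)c2ccc3[nH]c(-c4cc5ccccc5nc4O)cc3c2)C1`) keeps the sulfonyl but has 3-aminopyrrolidin-1-yl in place of 4-methylpiperazin-1-yl on a sulfonyl sulfur. The steps of a 5.8-fold higher number from compound 1 to compound 3 (0.76 log units; beyond the scatter) and a 3.8-fold higher number from compound 2 to compound 3 (0.58 log units; beyond the scatter) bear on this, but each also replaces a carbonyl with the sulfonyl, so they are only partial guides. Only part of that rise is expected to reverse, so a 2.1-fold lower number from compound 3 to compound 4 (0.33 log units; beyond the scatter) is the estimated step in this assay and it points downward. The estimate for compound 4 is 3 h (range 1.3 h to 6.5 h).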

Compound 4, half-life: 3.4 h
Estimate against measurement, compound 4: 1.1-fold (0.05 log units) below; measured number inside the range.
By their numbers in this assay, from the lowest: compounds 1, 2, 4 and 3 (each within the scatter of the next, the first and the last beyond it).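

In this assay the new group on the sulfonyl sulfur gives a small step (a 1.9-fold lower number from compound 3 to compound 4 (0.27 log units; within the scatter)), so 3-aminopyrrolidin-1-yl and 4-methylpiperazin-1-yl cannot be told apart here. With 3-aminopyrrolidin-1-yl kept, sulfonyl in place of carbonyl gives a step beyond the scatter (a 3.1-fold higher number from compound 1 to compound 4 (0.49 log units; beyond the scatter)), while the step from the carbamoyl compound stays within it (a 2.0-fold higher number from compound 2 to compound 4 (0.30 log units; within the scatter)). Nothing available explains these steps. Still open, from the compounds shown here alone, is how an open-chain amine such as dimethylamino, or a morpholine ring, would read on the same sulfonyl sulfur.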